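The compounds below may be only part of what the source reports. "The series", "measured", "known", "first", "only" and "open" are said of these compounds alone.

Measured so far:
compound 1 `O=C(Cn1c(=O)c(-c2ccc(O)c(O)c2)nc2ccccc21)NS(=O)(=O)C(F)(F)F`: 92.3%
compound 2 `O=C(Cn1c(=O)c(Oc2ccc(O)cc2)nc2ccccc21)NS(=O)(=O)C(F)(F)F`: 8.1%

Compound 2 holds the lower of the two numbers in a functional assay, tested at 100 uM; on this read-out lower numbers stand for a weaker effect and higher numbers for a stronger effect at the one concentration tested; compound 1 gives the higher number, and the step of a number 84.2 percentage points lower from compound 1 to compound 2 (beyond the scatter) lies beyond the scatter. Compound 3 `O=C(Cn1c(=O)c(/C=C/c2ccccc2)nc2ccccc21)NS(=O)(=O)C(F)(F)F` is not yet measured. It differs from compound 2 by 2-phenylethenyl in place of 4-hydroxyphenoxy on an aromatic carbon. Going by the values given here, no measured step covers this exchange: the only step in hand, a number 84.2 percentage points lower from compound 1 to compound 2 (beyond the scatter), concerns a different pair of groups at the same carbon and shows only that the read-out answers strongly to what stands there. Compound 2 is the nearest measured point, and nothing in the data points to a large move in either direction. For compound 3 a step of a number 6.9 percentage points higher from compound 2 to compound 3 (within the scatter) is expected, within the usual scatter. Compound 3 is therefore estimated at 15%, between 0% and 55%, a wide span given the absence of any comparable step.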

Compound 3, a percentage reported as activity, at one concentration (the size of the read-out at that concentration, not a potency): 58.5%
The estimate for compound 3 lay 43.5 percentage points below the measured number; the measured number lies above the stated range.
By their numbers in this assay, from the lowest: compound 2; then compound 3; then compound 1.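

In this assay the step of a number 50.4 percentage points higher from compound 2 to compound 3 (beyond the scatter) shows that a hydroxyl-bearing group is not needed at this carbon next to the ring nitrogen for a number well clear of that of compound 2, as 2-phenylethenyl has 0 hydrogen-bond donors and 0 hydrogen-bond acceptors. The step of a number 33.8 percentage points lower from compound 1 to compound 3 (beyond the scatter) still leaves 3,4-dihydroxyphenyl, the group of compound 1, highest of the three groups at this carbon. 4-Hydroxyphenoxy and 2-phenylethenyl each have 8 heavy atoms and one six-membered aromatic ring, so these counts alone do not set the read-out.

No measurement offered here explains the differences among these groups. Still open, as far as these compounds go, is whether the double bond matters, which 2-phenylethyl would test, and how a hydroxyl on the phenyl ring of 2-phenylethenyl, an amine or a carboxylic acid would fare at this carbon.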